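Notes on compounds 1 to 3 in the cell assay

A few compounds are considered here, and "the series" means these few. Any claim that something is new, unique, unknown or untested is made for them only; others in the source may bear on it.

Measured so far:
compound 1 `CCC(C)C(NC(=O)n1nnc2ccccc21)C(=O)NCc1ccccc1` — > 100000 nM
compound 2 `O=C1NC(c2ccccc2)C(=O)N1Cc1ccccc1` — 96800 nM

Going by the values given here, in a functional assay on SW-620 cells (Homo sapiens) for inhibition (a higher number here means a weaker inhibitor, a lower number a stronger inhibitor), compound 2 gives 96800 nM, the only outright number in hand. Compound 1 sits at the limit of > 100000 nM in this assay, at which 1 of the 2 values shown sits, a limit rather than a number. Compound 3 `CCC(C)C1NC(=O)N(Cc2ccccc2)C1=O` differs from compound 2 by sec-butyl in place of phenyl on a saturated ring carbon. Among the compounds with values here, no measured step covers this change; in this assay a step of modest size toward weaker inhibition is expected, possibly not beyond the scatter. Compound 3 is estimated at 150000 nM, between 40000 nM and 600000 nM. That expectation amounts to a 1.5-fold higher number from compound 2 to compound 3 (0.19 log units; within the scatter).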

Compound 3, half-maximal inhibitory concentration: > 100000 nM
Compound 3 gave a limit, no number; the forecaster's own chance of this, stated with the estimate: 60%; the middle value is on the limit's open side.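

In this assay, sec-butyl in place of phenyl on a saturated ring carbon gives an at least 1.0-fold higher number from compound 2 to compound 3 (0.01 log units; that floor lies within the scatter). Going by these compounds, compound 3 gave a limit, so this step is only a floor and its true size stays unknown. With sec-butyl, this position yields no measurable number, and the series now reaches the top of the read-out here: the limit of > 100000 nM in this assay, at which 2 of the 3 values shown sit.

Still open, on these data alone, is whether any group on this ring carbon can give a number clearly lower than that of compound 2. An amine, a carboxylic acid or a longer chain here would test this.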